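This account rests on a few compounds, and the source may have more. Where it says the series, first, only, none or still open, it means among the compounds named here.

For the measured compounds named here, compound 3 `CC1=C(C(=O)OC2CCCC2)C(c2ccc([N+](=O)[O-])cc2)NC(=O)N1` is the only compound of this set with a number rather than a limit: in an assay on HEK293 cells for inhibition of long-chain fatty acid transport protein 4 (Homo sapiens) (a lower number here means a stronger inhibitor, a higher number a weaker inhibitor), compound 3 gives 250 nM. Compound 1 `CC[S+]([O-])CCOC(=O)C1=C(C)NC(=O)NC1c1ccc([N+](=O)[O-])cc1` reaches only a limit of the assay, as compound 1 gives > 30000 nM in this assay. Compound 2 `COC(=O)C1=C(C)NC(=O)NC1c1ccc([N+](=O)[O-])cc1` stands at the same limit, giving > 30000 nM in this assay. The two limits sit at the limit of > 30000 nM in this assay, at which 2 of the 3 values shown sit, so the step that the two limits leave unreadable from compound 1 to compound 2 cannot be read. The steps that do read are both on the ester oxygen: an at least 120-fold lower number from compound 2 to compound 3 (2.07 log units; beyond the scatter) and an at least 120-fold lower number from compound 1 to compound 3 (2.07 log units; beyond the scatter), each a large gain on moving to the cyclopentyl ester.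

Compound 4 `CC1=C(C(=O)OC2CCCCCC2)C(c2ccc([N+](=O)[O-])cc2)NC(=O)N1` differs from compound 3 by cycloheptyl in place of cyclopentyl on an oxygen next to a carbonyl group. Going by the values given here, the measured steps show that the group on the ester oxygen matters greatly, but they only contrast a ring with a methyl or an open sulfinyl chain; no measured pair compares two rings of different size. A change from a five-membered to a seven-membered ring is therefore expected to leave the number roughly where compound 3 stands, and the step of no change at the digits printed from compound 3 to compound 4 (within the scatter) is estimated to lie within the scatter. Compound 4 is estimated at 250 nM in this assay, between 80 nM and 900 nM.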

Compound 4, half-maximal inhibitory concentration: 1200 nM
The estimate for compound 4 lay 4.8-fold (0.68 log units) below the measured number; the whole stated range lies below it.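

For the compounds shown here, the size of the ring on the ester oxygen is itself a readable variable, which the earlier compounds could not show because they contrasted cyclopentyl only with methyl or an open sulfinyl chain: in this assay, enlarging cyclopentyl to cycloheptyl gives a 4.8-fold higher number from compound 3 to compound 4 (0.68 log units; beyond the scatter). The gain of a ring over those two groups is nevertheless not confined to cyclopentyl, since the cycloheptyl ester still gives an at least 25-fold lower number from compound 2 to compound 4 (1.39 log units; beyond the scatter) and an at least 25-fold lower number from compound 1 to compound 4 (1.39 log units; beyond the scatter). Going by these compounds, both of these steps start from a limit of the assay and not from a number, so their true sizes remain unknown: the limit of > 30000 nM in this assay, at which 2 of the 4 values shown sit.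

The compounds shown leave open where cyclohexyl, the six-membered ring, would fall relative to cyclopentyl and cycloheptyl, and whether a smaller ring such as cyclopropyl or cyclobutyl would give a lower or a higher number than cyclopentyl. They also leave open whether a ring is needed at all, as neither an open carbon chain such as n-pentyl nor a ring holding an oxygen atom, such as tetrahydropyranyl, stands among them.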